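This account rests on a few compounds, and the source may have more. Where it says the series, first, only, none or still open, it means among the compounds named here.

In an ADME assay on HepG2 2.2.15 cells (Homo sapiens) for cytotoxicity, read by CCK-8 assay, with a stated time of 8 days (on this read-out lower numbers stand for higher toxicity in this test and higher numbers for lower toxicity in this test), three compounds have been measured. Compound 1 (`COc1ccc(-c2cc(NC(=O)c3cccc(OC)c3O)c[nH]c2=O)cc1`) gives 49200 nM, compound 2 (`CCOc1ccc(-c2cc(NC(=O)c3ccc(OC)cc3O)c[nH]c2=O)cc1`) gives 69600 nM, and compound 3 (`CCOc1ccc(-c2cc(NC(=O)c3ccc(F)cc3O)c[nH]c2=O)cc1`) gives 51500 nM. The value of compound 3 lies within the usual scatter of both others, so these numbers set no order among the three.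

The next compound to be tested is compound 4 (`CCOc1ccc(-c2cc(NC(=O)c3cccc(OC)c3O)c[nH]c2=O)cc1`), which has 2-hydroxy-3-methoxyphenyl in place of 4-fluoro-2-hydroxyphenyl on a carbonyl carbon.

For the measured compounds named here, only one measured step bears directly on this kind of change. In a 1.4-fold lower number from compound 2 to compound 3 (0.13 log units; within the scatter), fluoro replaces methoxy on an aromatic carbon, and the size of that step does not exceed the scatter. Compound 1 also bears on it, since it already carries the 2-hydroxy-3-methoxyphenyl group, though it differs from compound 4 elsewhere, and compound 1 gives 49200 nM. Neither observation points to a real shift in this assay, so no change beyond the scatter is expected. The expected move is a 1.1-fold higher number from compound 3 to compound 4 (0.03 log units; within the scatter), and its direction is not firmly indicated by the data.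

For compound 4 the estimated value is 55000 nM, with an expected range of 30000 nM to 100000 nM.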

Compound 4, half-maximal cytotoxic concentration: 34500 nM
For compound 4 the middle estimate is 1.6-fold (0.20 log units) above the measured one; the range from low to high includes it.
By their numbers in this assay, from the lowest: compounds 4, 1, 3 and 2 (each within the scatter of the next).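

Within this assay, the group on the carbonyl carbon was exchanged in two ways: 2-hydroxy-3-methoxyphenyl in place of 4-fluoro-2-hydroxyphenyl gives a 1.5-fold lower number from compound 3 to compound 4 (0.17 log units; within the scatter) and 2-hydroxy-3-methoxyphenyl in place of 2-hydroxy-4-methoxyphenyl gives a 2.0-fold lower number from compound 2 to compound 4 (0.30 log units; within the scatter), so at this place neither the exchange of fluoro for methoxy nor a different placing of the methoxy group leaves the scatter. For the compounds shown here, the new compound also gives the first reading of a change elsewhere in the molecule, for methyl in place of hydrogen on a saturated chain carbon bound to an oxygen on an aromatic ring gives a 1.4-fold lower number from compound 1 to compound 4 (0.15 log units; within the scatter), and this step too stays within the scatter. No independent evidence bears on these results.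

Going by these compounds, all four compounds keep a hydroxy group on the phenyl group at the carbonyl carbon, so it remains open whether a phenyl group without that hydroxy, or one carrying an amine or a carboxylic acid, would give a number beyond the scatter. On these data alone, it is equally open whether a longer chain on the oxygen would do so.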